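A few compounds are considered here, and "the series" means these few. Any claim that something is new, unique, unknown or untested is made for them only; others in the source may bear on it.

Measured compounds: compound 1 `O=C(O)CCCSCCN1C(=O)OC[C@@H]1/C=C/[C@@H](O)Cc1ccccc1` with 4.2 nM; compound 2 `Cc1cccc(C[C@H](O)/C=C/[C@H]2CCC(=S)N2CCSCCCC(=O)O)c1` with 0.5 nM.

In an assay on CHO cells for displacement of a labelled ligand from prostaglandin E2 receptor EP4 subtype (Mus musculus), read by scintillation counting, with a stated time of 60 min (a higher number here means a weaker inhibitor, a lower number a stronger inhibitor), compound 1 gives the higher of the two numbers; compound 2 gives a number lower by a margin beyond the usual scatter. The unmeasured compound 3 `O=C(O)CCCSCCN1C(=O)OC[C@@H]1/C=C/[C@@H](O)Cc1cccc(Cl)c1` differs from compound 1 in one place: chloro in place of hydrogen on an aromatic carbon. Going by the values given here, no measured pair shows this change on its own, so nothing in the data sets its size. Compound 3 is expected to sit somewhat lower than compound 1, a step of a 2.1-fold lower number from compound 1 to compound 3 (0.32 log units; beyond the scatter) near the edge of the scatter. The estimate for compound 3 in this assay is 2 nM, within 0.7 nM to 6 nM.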

Compound 3, inhibition constant: 1.5 nM
For compound 3 the middle estimate is 1.3-fold (0.12 log units) above the measured one; low and high end bracket the measured number.
By their numbers in this assay, from the lowest: compound 2; then compound 3; then compound 1.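

In this assay the change from phenyl to 3-chlorophenyl gives a 2.8-fold lower number from compound 1 to compound 3 (0.45 log units; beyond the scatter) as a modest step beyond the usual scatter. Going by these compounds alone, this is the first direct reading of this change, and it shows that this aromatic carbon of compound 1 accepts a chlorine atom with a lower number, not a higher one. Nothing measured here accounts for the size of the step.

From the compounds shown here alone, whether a fluoro, methyl or methoxy group in the same place would give a similar step stays open, as does the effect of chloro on other carbons of the ring.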